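The compounds below may be only part of what the source reports. "The series", "measured", "known", "first", "only" and "open" are said of these compounds alone.

Measured compounds: compound 1 `N/C(=N\NC(=S)N1CCCC1)c1ccc(F)cn1` gives 78.7%; compound 2 `N/C(=N\NC(=S)N1CCSCC1)c1ccc(F)cn1` gives 61.8%.

Both were tested in a functional assay on A-431 cells (Homo sapiens) for cytotoxicity, read by MTT assay, with a stated time of 72 h, tested at 10 uM; on this read-out higher numbers stand for more inhibition of growth at the one concentration tested and lower numbers for less inhibition of growth. Compound 2 has the lower of the two numbers. Going by the values given here, the only measured step is a number 16.9 percentage points lower from compound 1 to compound 2 (beyond the scatter), modest but beyond the scatter.

Compound 3 `N/C(=N\NC(=S)N1CCOCC1)c1ccc(F)cn1` differs from compound 2 by morpholin-4-yl in place of thiomorpholin-4-yl on a thiocarbonyl carbon. Among the compounds with values here, no measured step swaps these two rings, so the expectation rests on the one step known and stays uncertain. The step is expected to be a number 6.8 percentage points lower from compound 2 to compound 3 (within the scatter). For compound 3 the estimate in this assay is 55%, within 35% to 75%.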

Compound 3, percent growth inhibition at one concentration: 66.9%
Compound 3: middle estimate off by 11.9 percentage points, on the low side; the measured number falls inside the stated range.
By their numbers in this assay, from the lowest: compounds 2 and 3 (each within the scatter of the next); then compound 1.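

In this assay, putting the ring oxygen where the ring sulfur stood gives a number 5.1 percentage points higher from compound 2 to compound 3 (within the scatter) and so leaves the two six-membered rings on the thiocarbonyl carbon indistinguishable. Compared with the pyrrolidin-1-yl group, the morpholin-4-yl group gives a number 11.8 percentage points lower from compound 1 to compound 3 (beyond the scatter) and so, like thiomorpholin-4-yl, sits apart from compound 1. Nothing measured here explains these numbers.

From the compounds shown here alone, it stays open whether ring size or the second hetero atom matters, which piperidin-1-yl could separate. Going by these compounds, how an open-chain dimethylamino group would behave at this place is also open.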